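Chloro in Place of Bromo Across Two Cores

A few compounds are considered here, and "the series" means these few. Any claim that something is new, unique, unknown or untested is made for them only; others in the source may bear on it.

Four compounds share one change, bromo to chloro, set on two different cores. Compound 1 `NC(=O)NC(=O)c1ccc(F)c(NC(=O)CBr)c1` and compound 2 `NC(=O)NC(=O)c1ccc(F)c(NC(=O)CCl)c1` carry the first core; compound 3 `NC(=O)NC(=O)c1ccc(NC(=O)CBr)o1` and compound 4 `NC(=O)NC(=O)c1ccc(NC(=O)CCl)o1` carry the second. The difference between the two cores is not broken down here.

In a functional assay on CCRF-CEM cells (Homo sapiens) for antiproliferative activity, read by trypan blue exclusion, with a stated time of 72 h (a higher number here means a weaker inhibitor, a lower number a stronger inhibitor), compound 1 gives 2290 nM. Compound 2 reaches only a limit of the assay, > 20000 nM, and no number. Compound 3 gives 4050 nM in this assay; that value and the value of compound 1 lie within the usual scatter of each other, so no order between the two is claimed.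

Within the data shown here, the one measured step, an at least 8.7-fold higher number from compound 1 to compound 2 (0.94 log units; beyond the scatter), follows the change (chloro in place of bromo on a saturated chain carbon bound to a carbonyl carbon). The same change, at the same place, leads from compound 3 to compound 4: chloro in place of bromo on a saturated chain carbon bound to a carbonyl carbon. As far as these compounds go, whether the second core answers in the same way is exactly what remains open, and only the first pair speaks to it.

Compound 4 has not been measured in this assay. Applying a step of the size seen in an at least 8.7-fold higher number from compound 1 to compound 2 (0.94 log units; beyond the scatter) to the value of compound 3 carries the number past (the limit of > 20000 nM in this assay, at which 1 of the 3 values shown sits), so the assay may again report only a limit rather than a number. On that basis compound 4 is expected to give about 35000 nM, with a likely range from 15000 nM to 100000 nM. That estimate means an 8.6-fold higher number from compound 3 to compound 4 (0.94 log units; beyond the scatter).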

Compound 4, half-maximal inhibitory concentration: 16600 nM
For compound 4 the middle estimate is 2.1-fold (0.32 log units) above the measured one; the range from low to high includes it.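

In this assay the second core answers the change of chloro in place of bromo on a saturated chain carbon bound to a carbonyl carbon in the same direction as the first, with a 4.1-fold higher number from compound 3 to compound 4 (0.61 log units; beyond the scatter) as the result is weakened. This shows that in these two pairs the bromo compound is the stronger one on either core, but two pairs set no rule for the series, and whether the size of the step carries over from one core to the other is not shown: (the same change on two cores in this assay, an at least 8.7-fold higher number (0.94 log units; beyond the scatter) from compound 1 to compound 2 and a 4.1-fold higher number (0.61 log units; beyond the scatter) from compound 3 to compound 4; the limit leaves it open whether they differ). Compound 2 gives > 20000 nM as a limit of the assay and not a number, and it is the one value of that kind among those shown: (the limit of > 20000 nM in this assay, at which 1 of the 4 values shown sits).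

The compounds shown carry only bromo and chloro at this place, which leaves open how iodo, a plain hydrogen or an amine in the same spot would read in this assay, and whether a longer chain between the halogen and the carbonyl would keep the order seen here. They also leave open whether the same change would point the same way on any core other than these two.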